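From Hexyl to tert-Butyl on a Triple-Bonded Carbon

This account rests on a few compounds, and the source may have more. Where it says the series, first, only, none or still open, it means among the compounds named here.

In a functional assay on NIH3T3 cells (Mus musculus) (a higher number here means that more compound is needed for the effect, a lower number that less compound is needed), compound 3 (`CCCCCCC#Cc1cc(C#N)ccc1COC(c1ccc(C#N)cc1)c1cncn1C`) is reported only as a limit, > 0.1 nM. Compound 1 (`Cn1cncc1C(OCc1ccc(C#N)cc1C#Cc1ccccn1)c1ccc(C#N)cc1`) is also reported only as a limit, > 0.1 nM. Compound 2 (`CCC/C=C/C=C/c1cc(C#N)ccc1COC(c1ccc(C#N)cc1)c1cncn1C`) alone has a true number, 16.7 nM.

Compound 4 (`Cn1cncc1C(OCc1ccc(C#N)cc1C#CC(C)(C)C)c1ccc(C#N)cc1`) carries tert-butyl in place of hexyl on a triple-bonded carbon. Going by the values given here, three measured steps bear on this change. The closest is a step that the two limits leave unreadable from compound 1 to compound 3, which alters the same place. The others are a step that the limit leaves unreadable from compound 1 to compound 2 and a step that the limit leaves unreadable from compound 2 to compound 3. None of them gives a size, so the series fixes neither the size nor the direction of a step in this assay.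

The expectation therefore rests on compound 2, with its value of 16.7 nM, as the only numerical reference. The expected move is a step that the limit leaves unreadable from compound 3 to compound 4, and it may remain unreadable if another limit is reported. Compound 4 is estimated at 15 nM, with an expected range from 1.5 nM to 150 nM.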

Compound 4, half-maximal effective concentration: 76.9 nM
For compound 4 the middle estimate is 5.1-fold (0.71 log units) below the measured one, within the range that was stated.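

In this assay, going by these compounds alone, compound 4 supplies the second true number of the series, so a group on this aromatic carbon can for the first time be compared by size, with 3,3-dimethylbut-1-yn-1-yl in place of hepta-1,3-dien-1-yl giving a 4.6-fold higher number from compound 2 to compound 4 (0.66 log units; beyond the scatter). Compound 3, the direct partner for the change from hexyl to tert-butyl, is reported only as a limit, > 0.1 nM. The steps to compound 4 from compound 3 and from compound 1 therefore cannot be read, because each starts from a compound that stands only as a limit: the limit of > 0.1 nM in this assay, at which 2 of the 4 values shown sit.

From the compounds shown here alone, whether tert-butyl gives a higher or a lower number than hexyl or pyridin-2-yl on the triple-bonded carbon stays open. The compounds shown also leave open how a shorter chain such as propyl, or an amine carried on that carbon, would read in this assay.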